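The compounds below may be only part of what the source reports. "The series", "measured", "known", "first", "only" and "open" are said of these compounds alone.

Measured in an assay on HL-60 cells for inhibition of glutathione S-transferase P (Homo sapiens), read by spectrophotometry, tested at 20 uM; on this read-out higher numbers stand for more inhibition at the one concentration tested (going by the name of the read-out) and lower numbers for less inhibition:
compound 1, `Cc1cccc2c1N(CC(=O)O)C/C(=C\c1ccc(N(C)C)cc1)C2=O`: 13.2%
compound 2, `Cc1cccc2c1N(CC(=O)O)C/C(=C\c1cccc(O)c1)C2=O`: 75.6%
compound 3, `COc1ccc(/C=C2\CN(CC(=O)O)c3c(C)cccc3C2=O)c(OC)c1`: 11.7%

In this assay compound 3 gives the lowest of the three numbers. Compound 1 lies nearest, a little higher but within the scatter of repeated measurements, so the two cannot be ordered. Compound 2 lies far higher, well beyond the scatter.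

Compound 4 is `COc1ccc(/C=C2\CN(CC(=O)O)c3c(C)cccc3C2=O)cc1`. It differs from compound 3 in one place: hydrogen in place of methoxy on an aromatic carbon.

Among the measured compounds shown here, no step between measured compounds covers this change, so its size is a guess. Because compound 3 gives 11.7% and compound 1 gives 13.2%, both low, the step of a number 6.3 percentage points higher from compound 3 to compound 4 (within the scatter) is expected to stay within the scatter, upward if anything. Compound 4 is estimated at 18%, between 5% and 40%.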

Compound 4, a percentage reported as inhibition, at one concentration (the size of the read-out at that concentration, not a potency): 31.5%
Estimate against measurement, compound 4: 13.5 percentage points below; the range from low to high includes it.
By their numbers in this assay, from the lowest: compounds 3 and 1 (each within the scatter of the next); then compound 4; then compound 2.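

In this assay, hydrogen in place of methoxy on the aromatic carbon ortho to a large group gives a number 19.8 percentage points higher from compound 3 to compound 4 (beyond the scatter), so this position affects the read-out by more than the scatter. Methoxy in place of dimethylamino on an aromatic carbon gives a number 18.3 percentage points higher from compound 1 to compound 4 (beyond the scatter), while 4-methoxyphenyl in place of 3-hydroxyphenyl gives a number 44.1 percentage points lower from compound 2 to compound 4 (beyond the scatter), leaving the single methoxy well short of the 3-hydroxyphenyl compound. Nothing available explains these steps. Still open, on these data alone, is how hydroxy or fluorine on that same carbon would read, and whether a 4-hydroxyphenyl group would match 3-hydroxyphenyl.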